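Swapping bromo for methyl on a growth-inhibition scaffold

The source may hold more compounds than are shown below. What is called first, only, known or untested is meant among the compounds shown, and "the series" means these compounds.

Compound 2 `Nc1ccccc1NC(=O)c1ccc(CSc2ccc(Br)cc2)cc1` was tested in a functional assay on HeLa cells (Homo sapiens) for inhibition, read by CCK-8 assay, with a stated time of 72 h, tested at 2 uM (a lower number here means less inhibition of growth, a higher number more inhibition of growth at the concentration tested), where compound 2 gives 18.8%. Its only measured companion, compound 1 `COc1ccc(SCc2ccc(/C=C/C(=O)Nc3ccccc3N)cc2)cc1OC`, gives 10.1% in this assay; the two values sit within the usual scatter of each other, so neither can be called the more active. Compound 3 `Cc1ccc(SCc2ccc(C(=O)Nc3ccccc3N)cc2)cc1` is not yet measured. It differs from compound 2 by methyl in place of bromo on an aromatic carbon. Among the measured compounds shown here, no step between measured compounds covers such a swap, so the step from compound 2 to compound 3 is expected to be small, a number 0.8 percentage points lower from compound 2 to compound 3 (within the scatter), not clearly beyond the scatter in either direction. Compound 3 is therefore estimated at 18%, with a range from 7% to 32%.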

Compound 3, percent growth inhibition at one concentration: 33.8%
For compound 3 the middle estimate is 15.8 percentage points below the measured one, outside the stated range (above it).
By their numbers in this assay, from the lowest: compounds 1 and 2 (each within the scatter of the next); then compound 3.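

In this assay, methyl in place of bromo on the aromatic carbon para to a large group gives a number 15 percentage points higher from compound 2 to compound 3 (beyond the scatter) and so shows that this position responds to the group it carries. The two groups each have a single heavy atom and no hydrogen-bond donors or acceptors, yet the assay tells them apart. This modest step rests on one pair of compounds, and no measurement shown here accounts for it. On these data alone, how an amine, a carboxylic acid or a longer chain would fare at this position remains open. So does whether the same swap would give a similar step on the core of compound 1.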